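This account rests on a few compounds, and the source may have more. Where it says the series, first, only, none or still open, it means among the compounds named here.

Compound 3 `C=CCn1c(SC/C(=N/O)c2ccccc2)nnc1-c1cc(OC)c(OC)c(OC)c1` is one of three compounds tested in a functional assay on the whole organism (strain albino) for inhibition, with Rattus norvegicus as the target, read by paw edema, with a stated time of 5 h, at a dose of 0.28 mmol/kg by the oral route (a higher number here means more inhibition at the dose given (going by the name of the read-out), a lower number less inhibition), where compound 3 gives 77%. Compound 1 `COc1ccc(-c2nnc(SC/C(=N/O)c3ccccc3)n2-c2ccccc2)cc1OC` gives 78% and compound 2 `CCn1c(SC/C(=N/O)c2ccccc2)nnc1-c1cc(OC)c(OC)c(OC)c1` gives 74%; compound 3 stands second of the three, within the scatter of both. Compound 4 `COc1cc(-c2nnc(SC/C(=N/O)c3ccccc3)n2-c2ccccc2)cc(OC)c1OC` differs from compound 3 by phenyl in place of allyl on an aromatic nitrogen. Among the compounds with values here, the only measured step, a number 3 percentage points higher from compound 2 to compound 3 (within the scatter), exchanges groups on the same aromatic nitrogen and stays within the scatter, and compound 1, which also carries a phenyl on that nitrogen, reaches a number that lies within the scatter of compound 3. No step beyond the scatter is therefore expected, and the estimated step is a number 1 percentage points higher from compound 3 to compound 4 (within the scatter). For compound 4 the expected value in this assay is 78%, with a range from 68% to 87%.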

Compound 4, a percentage reported as inhibition, in the whole organism at one dose (the size of the read-out at that dose, not a potency): 68%
Compound 4: middle estimate off by 10 percentage points, on the high side, and the stated range covers the measured number.
By their numbers in this assay, from the lowest: compounds 4, 2, 3 and 1 (each within the scatter of the next).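

In this assay the step of a number 9 percentage points lower from compound 3 to compound 4 (within the scatter) with phenyl in place of allyl and the step of a number 6 percentage points lower from compound 2 to compound 4 (within the scatter) with phenyl in place of ethyl both stay within the scatter, so this aromatic nitrogen carries an aromatic ring as well as the two chains without a step beyond it. The step of a number 10 percentage points lower from compound 1 to compound 4 (within the scatter) with methoxy in place of hydrogen on an aromatic carbon also stays within the scatter. Nothing here gives a reason for these numbers. The compounds shown leave open whether a longer chain, a benzyl group or a chain ending in an amine on that nitrogen would give a step beyond the scatter.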